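This account rests on a few compounds, and the source may have more. Where it says the series, first, only, none or still open, it means among the compounds named here.

Measured so far in a functional assay on HepG2 cells (Homo sapiens) for cytotoxicity, read by MTT assay, with a stated time of 48 h (on this read-out higher numbers stand for weaker inhibition and lower numbers for stronger inhibition), as follows

compound 1 `Cc1ncc([N+](=O)[O-])n1CCSc1nnc(-c2ccc(N)cc2)o1` gives 6700 nM
compound 2 `Cc1ncc([N+](=O)[O-])n1CCSc1nnc(-c2ccc([N+](=O)[O-])cc2)o1` gives 4100 nM
compound 3 `Cc1ncc([N+](=O)[O-])n1CCSc1nnc(-c2ccc(N(C)C)cc2)o1` gives 11900 nM

Compound 1 stands within the scatter of both other compounds, with a 1.6-fold lower number from compound 1 to compound 2 (0.21 log units; within the scatter) and a 1.8-fold higher number from compound 1 to compound 3 (0.25 log units; within the scatter) as its two steps. Going by the values given here, the only step beyond the scatter is modest, a 2.9-fold higher number from compound 2 to compound 3 (0.46 log units; beyond the scatter), and does not involve compound 1. Compound 4 `Cc1ccc(-c2nnc(SCCn3c([N+](=O)[O-])cnc3C)o2)c(O)c1` is unmeasured and carries 2-hydroxy-4-methylphenyl in place of 4-aminophenyl (2-hydroxy-4-methylphenyl in place of 4-aminophenyl on an aromatic carbon). Among the compounds with values here, no measured step tests hydroxy or methyl, so these steps are only a loose guide. The steps from compound 1 stayed within the scatter, and a similarly small change is expected in this assay, with no step beyond the scatter. The expected step is a 1.1-fold lower number from compound 1 to compound 4 (0.05 log units; within the scatter), an estimate only. For compound 4 the estimated value is 6000 nM, with an expected range from 2200 nM to 15000 nM.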

Compound 4, half-maximal inhibitory concentration: 16600 nM
For compound 4 the middle estimate is 2.8-fold (0.44 log units) below the measured one; measured number above the stated range.
By their numbers in this assay, from the lowest: compounds 2, 1, 3 and 4 (each within the scatter of the next, the first and the last beyond it).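

In this assay, 2-hydroxy-4-methylphenyl in place of 4-aminophenyl gives a 2.5-fold higher number from compound 1 to compound 4 (0.39 log units; beyond the scatter) as the first step from compound 1 beyond the scatter, though only a modest one. Changing the aryl group on this carbon can therefore shift the number towards weaker inhibition, which the swaps of amino for nitro or dimethylamino did not show. Nothing available explains this shift. From the compounds shown here alone, the step changes hydroxy and methyl together, so their separate contributions remain open. Also open, going by these compounds, is how a carboxylic acid or a halogen such as chlorine would read on this phenyl ring.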